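Aryl swap on the hydrazone of a shared core

This account rests on a few compounds, and the source may have more. Where it says the series, first, only, none or still open, it means among the compounds named here.

Compound 1 `Nc1cccc(Nc2nc(N/N=C/c3ccc(F)cc3)ncc2Cl)c1`: 12300 nM in an ADME assay on HT-29 cells (Homo sapiens) for inhibition, read by MTT assay, with a stated time of 72 h; on this read-out lower numbers stand for stronger inhibition and higher numbers for weaker inhibition
Compound 2 `C=CC(=O)Nc1cccc(Nc2nc(N/N=C/c3ccccc3F)ncc2Cl)c1`: 3500 nM
Compound 3 `C=CC(=O)Nc1cccc(Nc2nc(N/N=C(\C)c3ccc(F)cc3F)ncc2Cl)c1`: 4360 nM

Among these three numbers compound 3 stands second highest. Compound 2 sits a short distance below it, within the scatter, so no order between compound 2 and compound 3 can be claimed; compound 1 lies further off, beyond the scatter, with the higher number. Compound 4 `C=CC(=O)Nc1cccc(Nc2nc(N/N=C(\C)c3cccc(OC)c3)ncc2Cl)c1` differs from compound 3 by 3-methoxyphenyl in place of 2,4-difluorophenyl on a carbon with a double bond to nitrogen. Going by the values given here, no pair of measured compounds shows this change, so its size in this assay is unknown; a step no larger than the scatter is expected, in either direction. Compound 4 is therefore estimated at 4500 nM, with a range from 1500 nM to 14000 nM. The expected step is a 1.0-fold higher number from compound 3 to compound 4 (0.01 log units; within the scatter), close to none.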

Compound 4, half-maximal inhibitory concentration: 8990 nM
Compound 4: the middle estimate sits 2.0-fold (0.30 log units) below what was measured, and the stated range covers the measured number.
By their numbers in this assay, from the lowest: compounds 2 and 3 (each within the scatter of the next); then compounds 4 and 1 (each within the scatter of the next).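

With this step, the aryl group on the carbon with a double bond to nitrogen is seen to matter in this assay: 3-methoxyphenyl in place of 2,4-difluorophenyl gives a modest change beyond the scatter (a 2.1-fold higher number from compound 3 to compound 4 (0.31 log units; beyond the scatter)). The earlier compounds shown here offered no single-place comparison to show this. No measurement at hand accounts for the shift.

The compounds shown leave open whether the step follows from losing the fluorines or from gaining the methoxy group. From the compounds shown here alone, how an unsubstituted phenyl or a phenyl carrying an amine or a carboxylic acid would read at this place also remains open.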